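Swapping the chain on the ring nitrogen of compound 3

A few compounds are considered here, and "the series" means these few. Any claim that something is new, unique, unknown or untested is made for them only; others in the source may bear on it.

In a functional assay on CHO cells for positive allosteric modulation of metabotropic glutamate receptor 2 (Homo sapiens), read by scintillation counting and GTPgammaS binding, with a stated time of 30 min (a lower number here means that less compound is needed, a higher number that more compound is needed for the effect), compound 1 `Cc1ncccc1Oc1ccc(-c2ccn(CC3CC3)c(=O)c2C#N)cc1` gives 1070 nM, compound 2 `CCCCn1ccc(-c2ccc(Oc3ccc(C)nc3C)cc2)c(C#N)c1=O` gives 138 nM, and compound 3 `Cc1ccc(Oc2ccc(-c3ccn(CCC(C)C)c(=O)c3C#N)cc2)c(C)n1` gives 100 nM, the lowest of the three, with compound 2 nearest and compound 1 furthest away. For the measured compounds named here, the only single step among them, a 1.4-fold lower number from compound 2 to compound 3 (0.14 log units; within the scatter), sits within the scatter. Compound 4 `Cc1ccc(Oc2ccc(-c3ccn(CC4CC4)c(=O)c3C#N)cc2)c(C)n1` differs from compound 3 by cyclopropyl in place of isobutyl on a saturated chain carbon bound to an aromatic nitrogen. Compound 1 carries the same cyclopropyl on a saturated chain carbon bound to an aromatic nitrogen, but also a different pyridine, so its value bears only loosely. The step of a 2.0-fold higher number from compound 3 to compound 4 (0.30 log units; within the scatter) is expected to be small and toward a higher number, so compound 4 is estimated at 200 nM, between 70 nM and 600 nM.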

Compound 4, half-maximal effective concentration: 263 nM
For compound 4 the middle estimate is 1.3-fold (0.12 log units) below the measured one, within the range that was stated.
By their numbers in this assay, from the lowest: compounds 3, 2 and 4 (each within the scatter of the next, the first and the last beyond it); then compound 1.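

For the compounds shown here, with cyclopropyl at this place in this assay, there is a 2.6-fold higher number from compound 3 to compound 4 (0.42 log units; beyond the scatter), the first step here beyond the scatter for a change of chain on a saturated chain carbon bound to an aromatic nitrogen, whereas a 1.9-fold higher number from compound 2 to compound 4 (0.28 log units; within the scatter) stays within it. With that chain held the same, methyl in place of hydrogen on an aromatic carbon gives a 4.1-fold lower number from compound 1 to compound 4 (0.61 log units; beyond the scatter), so the change away from the chain also moves the number beyond the scatter. Nothing available explains these steps.

The compounds shown leave open how a longer chain or an amine-bearing chain would read at this place. They also leave open whether the methyl step would hold with isobutyl in place of cyclopropyl.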